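The source may hold more compounds than are shown below. What is called first, only, known or untested is meant among the compounds shown, and "the series" means these compounds.

Measured compounds:
Compound 1, `COc1ccc(OCCCON2C(N)=NC(N)=NC23CCOCC3)cc1`: 1670 nM
Compound 2, `NC1=NC2(CCOCC2)N(OCCCOc2ccc(Cl)cc2)C(N)=N1`: 330 nM
Compound 3, `NC1=NC2(CCSCC2)N(OCCCOc2ccc(Cl)cc2)C(N)=N1`: 430 nM

The three compounds were tested in a functional assay on HL-60 cells (Homo sapiens) for antiproliferative activity, read by MTT assay, with a stated time of 72 h; a lower number here means a stronger inhibitor, a higher number a weaker inhibitor. Compound 2 gives 330 nM there, and compound 3 gives 430 nM, two numbers that lie within the scatter of each other, so no order between them is claimed. Compound 1 gives 1670 nM, the highest of the three numbers.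

Compound 1 is made from compound 2 by one change, (methoxy in place of chloro on an aromatic carbon), and that change produced a 5.1-fold higher number from compound 2 to compound 1 (0.70 log units; beyond the scatter). The difference between the core of compound 2 and the core of compound 3 is not broken down here.

Compound 4, `COc1ccc(OCCCON2C(N)=NC(N)=NC23CCSCC3)cc1`, has not been measured. It stands to compound 3 as compound 1 stands to compound 2: the change is methoxy in place of chloro on an aromatic carbon, on the same place, so it is the same change made on the other core. Because the earlier step was a 5.1-fold higher number from compound 2 to compound 1 (0.70 log units; beyond the scatter), a step of similar size is expected here, giving a 5.1-fold higher number from compound 3 to compound 4 (0.71 log units; beyond the scatter) from compound 3 to compound 4 in this assay. On that basis compound 4 is estimated at 2200 nM in this assay, expected to fall between 900 nM and 5500 nM. Within the data shown here, only one earlier instance of the change supports this expectation, so the range is kept wide.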

Compound 4, half-maximal inhibitory concentration: 500 nM
For compound 4 the middle estimate is 4.4-fold (0.64 log units) above the measured one, and the stated range ends above it.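

Carried onto the core of compound 3, the replacement of chloro by methoxy gives a 1.2-fold higher number from compound 3 to compound 4 (0.07 log units; within the scatter) in this assay, so the clear rise seen on the core of compound 2 does not recur on this core. The change therefore does not carry over at a constant size between these two cores: the same change on two cores in this assay, a 5.1-fold higher number (0.70 log units; beyond the scatter) from compound 2 to compound 1 and a 1.2-fold higher number (0.07 log units; within the scatter) from compound 3 to compound 4, 4.4-fold (0.64 log units) apart, beyond the scatter of two such steps

This comparison rests on a single pair on each core, so it shows only that the 4-chlorophenyl to 4-methoxyphenyl step differs between these two cores in this one assay; it does not show what in the cores accounts for the gap, nor which of the two steps, if either, the same change would resemble on a further core.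

The compounds shown leave open how other groups at the same place on the aromatic ring, such as fluoro, methyl or a nitrile, would behave on the two cores, and whether their steps would also differ from one core to the other. They also leave open whether the gap between the two steps would persist with a shorter or a longer chain in place of the present one.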